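A few compounds are considered here, and "the series" means these few. Any claim that something is new, unique, unknown or untested is made for them only; others in the source may bear on it.

Measured compounds

Compound 1, `COc1nc(-c2cccc(Cl)c2)ccc1[C@@H](c1ccccc1)[C@@](O)(CCN(C)C)c1cccc2ccccc12`; in a toxicity assay on Vero cells (Chlorocebus sabaeus) for cytotoxicity (on this read-out higher numbers stand for lower toxicity in this test and lower numbers for higher toxicity in this test), compound 1 gives > 50 ug/mL, which is a limit of the assay and not a number.
Compound 2, `COc1nc(-c2ccc(OC(F)(F)F)cc2)ccc1[C@@H](c1ccccc1)[C@@](O)(CCN(C)C)c1cccc2ccccc12`; in this assay compound 2 gives > 50 ug/mL, again a limit of the assay.

Where compound 2 stands: only a limit is known for it, and the one other value shown is a limit as well, so the limit of > 50 ug/mL in this assay, at which 2 of the 2 values shown sit, is the whole of the evidence in this assay. Going by the values given here, the single measured step, a step that the two limits leave unreadable from compound 1 to compound 2, is therefore unreadable in size.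

Compound 3 is `COc1nc(-c2ccc(Cl)cc2)ccc1[C@@H](c1ccccc1)[C@@](O)(CCN(C)C)c1cccc2ccccc12`. The change from compound 2 is chloro in place of trifluoromethoxy on an aromatic carbon. Among the compounds with values here, no measured step bears on this change, and the step that is measured gives no size to work from. Compound 2 at its limit, > 50 ug/mL, is the only anchor.

The step from compound 2 to compound 3 in this assay is expected to be a step that the limit leaves unreadable from compound 2 to compound 3, that is, no shift beyond the scatter. Compound 3 is expected to give 60 ug/mL in this assay, with a range of 25 ug/mL to 150 ug/mL, most likely again reported as a limit.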

Compound 3, half-maximal cytotoxic concentration: > 50 ug/mL
Compound 3 gave a limit, no number; the forecaster's own chance of this, stated with the estimate: 80%; the middle value lies beyond the limit too.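

In this assay, going by these compounds alone, compound 1, compound 2 and compound 3 all stand at a limit of the assay and not at a number, so no step among them can be read: the limit of > 50 ug/mL in this assay, at which 3 of the 3 values shown sit.

The compounds shown leave open whether any of the three differs from the others in this assay, and at what concentration any of them becomes cytotoxic.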